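A few compounds are considered here, and "the series" means these few. Any claim that something is new, unique, unknown or untested is made for them only; others in the source may bear on it.

Measured compounds:
compound 1, `Cc1ccc(NC(=S)N/N=C2\C(=O)N(Cc3ccc(F)cc3)c3ccc(F)cc32)cc1`: compound 1 gives 6200 nM in a functional assay on L1210 cells (Mus musculus), with a stated time of 48 h; on this read-out lower numbers stand for stronger inhibition and higher numbers for weaker inhibition
compound 2, `O=C1/C(=N\NC(=S)Nc2ccc(Cl)cc2)c2cc(Br)ccc2N1Cc1ccc(F)cc1`: compound 2 gives 196000 nM in this assay

Compound 2 stands at the highest of the two measured numbers in this assay; the nearest, compound 1, sits far lower, and that gap is beyond the scatter. Going by the values given here, compounds 1 and 2 differ in two places, so no single-change step between them is known; their two values only show that the pair of changes taken together moves the read-out strongly.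

Compound 3, `Cc1ccc(NC(=S)N/N=C2\C(=O)N(Cc3ccc(F)cc3)c3ccc(Br)cc32)cc1`, is to be measured in this assay. It arises from compound 2 by methyl in place of chloro on an aromatic carbon. Compound 3 thus carries the (4-methylphenyl)amino group of compound 1 on the core of compound 2. Among the compounds with values here, no step between measured compounds isolates this change, so its size is uncertain. A downward move, beyond the scatter, is expected for compound 3 because compound 1 with the same (4-methylphenyl)amino group reads 6200 nM, though part of that gap may belong to the other difference. The expected step of a 6.5-fold lower number from compound 2 to compound 3 (0.82 log units; beyond the scatter) is accordingly a large fall. Compound 3 is estimated at 30000 nM, with a range of 6000 nM to 150000 nM.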

Compound 3, half-maximal inhibitory concentration: 190000 nM
Compound 3: middle estimate off by 6.3-fold (0.80 log units), on the low side; the measured number lies above the stated range.
By their numbers in this assay, from the lowest: compound 1; then compounds 3 and 2 (each within the scatter of the next).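

With bromo held on the shared core in this assay, the change from (4-chlorophenyl)amino to (4-methylphenyl)amino gives no readable shift (a 1.0-fold lower number from compound 2 to compound 3 (0.01 log units; within the scatter)), so methyl and chloro cannot be told apart at this position on this core. With the (4-methylphenyl)amino group held fixed, bromo in place of fluoro on an aromatic carbon of the core gives a large step (a 31-fold higher number from compound 1 to compound 3 (1.49 log units; beyond the scatter)), which places the wide gap between compound 1 and compound 2 with the halogen on the core and not with the swap of chloro for methyl, for these three compounds. No supporting measurement bears on this result, and the size of the halogen step stays unexplained.

From the compounds shown here alone, whether methyl and chloro also read alike on the fluoro-bearing core of compound 1 remains open, since the two changes are seen together only in compound 2 and one step cannot show whether they act independently. Also open, going by these compounds, is how the read-out responds to other groups at this position, such as methoxy, an amine or a carboxylic acid, and to hydrogen or chloro in place of the halogen on the core.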